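The compounds below may be only part of what the source reports. "The series", "measured", "known", "first", "only" and "open" are said of these compounds alone.

The series shares one core, seen in compound 1 `CCOC(=O)c1c(CN(CC)Cc2ccccc2)nc2ccccc2c1-c1ccccc1`, for which an assay on brain with Translocator protein (Rattus norvegicus) as the target (a higher number here means a weaker inhibitor, a lower number a stronger inhibitor), gives compound 1 700 nM. Compound 2 `CCN(Cc1ccccc1)Cc1nc2ccccc2c(-c2ccccc2)c1C(=O)N(C)C` gives 229 nM in this assay, and compound 3 `CCN(Cc1ccccc1)Cc1nc2ccccc2c(-c2ccccc2)c1C(=O)N(C)c1ccc(Cl)cc1` gives 2480 nM. Compound 3 carries the highest number of the three: one step reads a 3.5-fold higher number from compound 1 to compound 3 (0.55 log units; beyond the scatter), and the other reads an 11-fold higher number from compound 2 to compound 3 (1.03 log units; beyond the scatter). Not yet measured is compound 4 `CCN(Cc1ccccc1)Cc1nc2ccccc2c(-c2ccccc2)c1C(=O)N(C)c1ccccc1`, which differs from compound 3 only in hydrogen in place of chloro on an aromatic carbon. Among the measured compounds shown here, no measured step removes a chloro alone, so the bearing of the earlier steps is indirect. The step of an 11-fold higher number from compound 2 to compound 3 (1.03 log units; beyond the scatter) shows what the whole 4-chlorophenyl in place of methyl on the amide-type nitrogen did, while the step of a 3.1-fold lower number from compound 1 to compound 2 (0.49 log units; beyond the scatter) brought a modest gain. How much of the large step belongs to the chloro alone cannot be read from these three compounds. For compound 4 a modest drop in number is expected, a 1.7-fold lower number from compound 3 to compound 4 (0.22 log units; within the scatter). Compound 4 is estimated at 1500 nM in this assay, with a range from 600 nM to 4000 nM.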

Compound 4, half-maximal inhibitory concentration: 1320 nM
For compound 4 the middle estimate is 1.1-fold (0.06 log units) above the measured one; measured number inside the range.
By their numbers in this assay, from the lowest: compound 2; then compounds 1, 4 and 3 (each within the scatter of the next, the first and the last beyond it).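

In this assay, hydrogen in place of chloro on the aromatic carbon gives a 1.9-fold lower number from compound 3 to compound 4 (0.27 log units; within the scatter), so this position, para to a large group, does not separate the two atoms. The loss seen with the 4-chlorophenyl group therefore does not need the chloro: phenyl in place of methyl on the amide-type nitrogen already gives a 5.8-fold higher number from compound 2 to compound 4 (0.76 log units; beyond the scatter), while methyl(phenyl)amino in place of ethoxy on the carbonyl carbon gives a 1.9-fold higher number from compound 1 to compound 4 (0.28 log units; within the scatter), leaving these two carbonyl substituents unresolved. No measurement at hand accounts for the penalty of the phenyl group.

Open, going by these compounds, is whether a methoxy group or a carboxylic acid on the same aromatic carbon would give a step beyond the scatter. Also open, on these data alone, is how an ethyl or benzyl group on the amide-type nitrogen would compare with methyl and phenyl.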